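The source may hold more compounds than are shown below. What is called first, only, known or untested is meant among the compounds shown, and "the series" means these compounds.

The measured compounds:

Compound 1 `COCOc1cc(/C=C/C(=O)OCC(=O)NCc2ccco2)ccc1OCc1ccccc1`: > 200000 nM
Compound 2 `CCOc1ccc(COc2c(OC)cc(/C=C/C(=O)OCC(=O)Nc3ccc(Cl)cc3)cc2OC)cc1`: > 200000 nM
Compound 3 `CCOc1ccc(COc2c(OC)cc(/C=C/C(=O)N3CCN(Cc4ccc(Cl)c(Cl)c4)CC3)cc2OC)cc1`: > 200000 nM

All three values come from a functional assay on LS174T cells (Homo sapiens) for cytotoxicity, read by MTT assay, with a stated time of 72 h; a higher number here means a weaker inhibitor, a lower number a stronger inhibitor. For compound 1 the figure recorded in this assay is a limit of the assay and not a number. For compound 2 the figure in this assay is likewise a limit of the assay. For compound 3 the figure in this assay is also a limit of the assay. So compound 1 stands nowhere that can be ranked: it sits where every value shown sits, as the limit of > 200000 nM in this assay, at which 3 of the 3 values shown sit, makes plain. Among the measured compounds shown here, no step between measured compounds can be drawn from such figures, and nothing marks any one of the three as stronger or weaker than another.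

The compound still to be measured is compound 4 `COCOc1cc(/C=C/C(=O)OCC(=O)Nc2nccs2)ccc1OCc1ccccc1`. It differs from compound 1 in one place: 1,3-thiazol-2-yl in place of (furan-2-yl)methyl on an amide-type nitrogen. With the shared core of compound 1 unchanged and every value shown sitting at the limit, the estimate for compound 4 in this assay is 200000 nM, expected to fall between 100000 nM and 400000 nM. The expected step is a number no higher from compound 1 to compound 4 (the limit leaves the size open), that is, none beyond the usual scatter, with a second limit the most likely outcome.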

Compound 4, half-maximal inhibitory concentration: > 200000 nM
Compound 4 was reported as a limit; the forecaster's own chance of this, stated with the estimate: 85%; the middle value sits exactly at the limit.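

No step can be read from compound 1 to compound 4 in this assay, as both figures are limits of the assay and not numbers: the limit of > 200000 nM in this assay, at which 4 of the 4 values shown sit.

The compounds shown leave open whether 1,3-thiazol-2-yl and (furan-2-yl)methyl on the amide-type nitrogen differ at all in this assay, and what numerical value any of these compounds would give there.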